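A few compounds are considered here, and "the series" means these few. Any claim that something is new, unique, unknown or untested is made for them only; others in the source may bear on it.

Measured so far in a functional assay on HeLa cells (Homo sapiens) for inhibition, read by sulforhodamine B assay (on this read-out higher numbers stand for weaker inhibition and lower numbers for stronger inhibition), on the shared core:
- compound 1 `O=C1C(Nc2ccccc2)=CC(=O)c2c1nc1n2[C@H]2OC[C@@H](O)[C@H]2OC1` gives > 8000 nM (a limit)
- compound 2 `COc1ccccc1NC1=CC(=O)c2c(nc3n2[C@H]2OC[C@@H](O)[C@H]2OC3)C1=O` gives 7460 nM

Among the compounds with values here, compound 2 gives 7460 nM as the only actual number so far. Compound 1 stands only at a limit: the limit of > 8000 nM in this assay, at which 1 of the 2 values shown sits, applies to it. Within the data shown here, the one measured step of an at least 1.0-fold lower number from compound 1 to compound 2 (0.03 log units; that floor lies within the scatter) lies within the scatter and concerns methoxy in place of hydrogen on an aromatic carbon. Compound 3 `O=C1C(N2CCC2)=CC(=O)c2c1nc1n2[C@H]2OC[C@@H](O)[C@H]2OC1` differs by azetidin-1-yl in place of (2-methoxyphenyl)amino on a double-bonded ring carbon and so has azetidin-1-yl in place of (2-methoxyphenyl)amino on a double-bonded ring carbon. Among the measured compounds shown here, no measured step tests this replacement, so with compound 2 at 7460 nM no step beyond the scatter is expected in this assay for it. The expected step of a 1.5-fold lower number from compound 2 to compound 3 (0.17 log units; within the scatter) is a weakly founded estimate. Compound 3 is estimated at 5000 nM (expected range 1500 nM to 16000 nM).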

Compound 3, half-maximal inhibitory concentration: > 16000 nM
Compound 3 ended at the assay's limit; the forecaster's own chance of this, stated with the estimate: 35%; at least 3.2-fold (0.50 log units) between middle value and limit.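

In this assay, within the data shown here, azetidin-1-yl in place of (2-methoxyphenyl)amino on this double-bonded ring carbon gives an at least 2.1-fold higher number from compound 2 to compound 3 (0.33 log units; beyond the scatter), the first readable step beyond the scatter. This position therefore responds to a change of group, and the azetidin-1-yl of compound 3 does not keep the number of compound 2. Compound 3 stands only at a limit: the limit of > 16000 nM in this assay, at which 1 of the 3 values shown sits.

The step between compound 1 and compound 3 cannot be read, as both values are limits. On these data alone, whether the six-membered aromatic ring or the amine hydrogen carries the difference remains open, as does the outcome with an open-chain amine such as benzylamino or a larger ring such as morpholin-4-yl on this carbon.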